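The compounds below may be only part of what the source reports. "The series", "measured", "known", "first", "only" and "open" are said of these compounds alone.

Measured in a functional assay on A549 cells (Homo sapiens) for antiproliferative activity, read by MTT assay, with a stated time of 24 h; on this read-out lower numbers stand for stronger inhibition and higher numbers for weaker inhibition:
- compound 1 `O=C(NNc1cccc(Cl)c1)c1ccc(NS(=O)(=O)c2cnc(O)nc2O)cc1`: 7290 nM
- compound 2 `Cc1ccccc1C(=O)NNC(=O)c1ccc(NS(=O)(=O)c2cnc(O)nc2O)cc1`: 15100 nM

Compound 2 gives 15100 nM, the higher of the two numbers and so the weaker inhibition of the pair. Going by the values given here, its only neighbour is compound 1, and the gap is a 2.1-fold higher number from compound 1 to compound 2 (0.32 log units; beyond the scatter). That modest step is the only measured one in the series.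

Next is compound 3 `Cc1ccc(C(=O)NNC(=O)c2ccc(NS(=O)(=O)c3cnc(O)nc3O)cc2)cc1`, an isomer of compound 2 with the same atoms joined differently: 4-methylphenyl in place of 2-methylphenyl on a carbonyl carbon. The change is 4-methylphenyl in place of 2-methylphenyl on a carbonyl carbon.

The measured step bears on this only loosely. Among the compounds with values here, it replaces 3-chlorophenyl on an amine nitrogen with (2-methylphenyl)carbonyl, and no measured pair compares the two methylphenyl groups. It therefore serves only as a rough guide to size, and the data give no direction. In this assay a step no larger than that one is expected, quite possibly none beyond the scatter.

The expected change is a 1.2-fold lower number from compound 2 to compound 3 (0.07 log units; within the scatter). For compound 3 the estimated value is 13000 nM, with an expected range of 5500 nM to 30000 nM.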

Compound 3, half-maximal inhibitory concentration: 15900 nM
Beside the measured number, compound 3's estimate is 1.2-fold (0.09 log units) below it; the range from low to high includes it.
By their numbers in this assay, from the lowest: compound 1; then compounds 2 and 3 (each within the scatter of the next).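

In this assay, 4-methylphenyl in place of 2-methylphenyl on a carbonyl carbon gives a 1.1-fold higher number from compound 2 to compound 3 (0.02 log units; within the scatter) and so leaves the read-out within the scatter: at this position, the two methylphenyl isomers cannot be told apart. The step to the (4-methylphenyl)carbonyl group from 3-chlorophenyl on an amine nitrogen gives a 2.2-fold higher number from compound 1 to compound 3 (0.34 log units; beyond the scatter) and is of about the same modest size as a 2.1-fold higher number from compound 1 to compound 2 (0.32 log units; beyond the scatter) for the (2-methylphenyl)carbonyl group, so the gap to compound 1 appears with either isomer. Nothing at hand offers an explanation for these numbers.

The compounds shown leave open whether 3-methylphenyl on the same carbonyl carbon would fall with compound 2 and compound 3, and whether a methoxy group, a chlorine atom or a carboxylic acid on that phenyl ring would shift the read-out beyond the scatter. They also leave open how much of the gap to compound 1 belongs to the added carbonyl and how much to the chlorine atom, as both differ in the same step.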